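Swapping the Pyridine Substituent on a Sulfonamide Nitrogen

The compounds below may be only part of what the source reports. "The series", "measured", "known", "first", "only" and "open" are said of these compounds alone.

Within the data shown here, compound 2 `O=S(=O)(CSc1nnc(Br)n1Cc1ccc(Br)c2ccccc12)Nc1cncc(C(F)(F)F)c1` is the stronger of the two compounds measured so far in an assay on HEK293 cells for inhibition of solute carrier family 22 member 12 (Homo sapiens); on this read-out lower numbers stand for stronger inhibition and higher numbers for weaker inhibition: compound 2 gives 6380 nM, while compound 1 `Oc1c(Br)cc(CSc2nnc(Br)n2Cc2ccc(Br)c3ccccc23)cc1Br` gives 119000 nM, a weaker result that lies beyond the scatter. Compound 3 `O=S(=O)(CSc1nnc(Br)n1Cc1ccc(Br)c2ccccc12)Nc1cccnc1Cl` has not been measured. It differs from compound 2 in one place: 2-chloropyridin-3-yl in place of 5-(trifluoromethyl)pyridin-3-yl on a sulfonamide nitrogen. Both groups are a six-membered aromatic ring carrying one halogen-containing substituent, and the rest of the molecule, including the sulfonamide and the shared core, is unchanged. Among the measured compounds shown here, no measured pair shows this exact change, so the size of the step is uncertain. Because compound 2 gives 6380 nM and the change is modest, compound 3 is expected to stay close, with the step of a 1.4-fold higher number from compound 2 to compound 3 (0.15 log units; within the scatter) expected to fall within the usual scatter. The estimate for compound 3 in this assay is 9000 nM, with a range from 3000 nM to 30000 nM.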

Compound 3, half-maximal inhibitory concentration: 5100 nM
Estimate against measurement, compound 3: 1.8-fold (0.25 log units) above; the range from low to high includes it.
By their numbers in this assay, from the lowest: compounds 3 and 2 (each within the scatter of the next); then compound 1.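

In this assay, putting 2-chloropyridin-3-yl in place of 5-(trifluoromethyl)pyridin-3-yl on a sulfonamide nitrogen gives a 1.3-fold lower number from compound 2 to compound 3 (0.10 log units; within the scatter) and so leaves the two compounds indistinguishable on this read-out. Among these compounds, this is the first direct comparison at this position, and it shows that a group with fewer heavy atoms, carrying chlorine rather than trifluoromethyl, gives a result that cannot be separated from the original. Nothing available explains why these two groups read alike.

The compounds shown leave open how this nitrogen would respond to a pyridine ring carrying an amine or a carboxylic acid, or to a plain phenyl ring. They also leave open whether the same exchange would read alike if the shared core were changed.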